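A few compounds are considered here, and "the series" means these few. Any claim that something is new, unique, unknown or untested is made for them only; others in the source may bear on it.

Compound 1 `Cc1ccccc1-c1cccc(-c2cc3nc(C)c([C@H](OC(C)(C)C)C(=O)O)c(-c4cc(F)c5c(c4C)CCCO5)n3n2)c1`: 7.1 mL/min/kg
Compound 2 `COc1ccccc1-c1cccc(-c2cc3nc(C)c([C@H](OC(C)(C)C)C(=O)O)c(-c4cc(F)c5c(c4C)CCCO5)n3n2)c1`: 28 mL/min/kg

In an ADME assay on the whole organism (Rattus norvegicus, strain Sprague-Dawley) for pharmacokinetics, read by LC-MS, with a stated time of 10 min (a higher number here means faster removal of the compound, a lower number slower removal), compound 2 has the higher of the two numbers, at 28 mL/min/kg. Compound 3 `Cc1nc2cc(-c3cccc(-c4ccccc4F)c3)nn2c(-c2cc(F)c3c(c2C)CCCO3)c1[C@H](OC(C)(C)C)C(=O)O` differs from it in one place: fluoro in place of methoxy on an aromatic carbon, ortho to a large group. For the measured compounds named here, the only measured step at this place is a 3.9-fold higher number from compound 1 to compound 2 (0.60 log units; beyond the scatter), with methoxy in place of methyl. Fluoro itself is untested, but losing methoxy is expected to reverse much of that step. The expected step is a 2.2-fold lower number from compound 2 to compound 3 (0.33 log units; beyond the scatter). For compound 3 the estimated value is 13 mL/min/kg, within an expected range of 6 mL/min/kg to 28 mL/min/kg.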

Compound 3, clearance: 13 mL/min/kg
Compound 3: middle estimate and measured number agree at the digits printed; low and high end bracket the measured number.
By their numbers in this assay, from the lowest: compounds 1 and 3 (each within the scatter of the next); then compound 2.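

Changing the 2-methoxyphenyl to the 2-fluorophenyl gives a 2.2-fold lower number from compound 2 to compound 3 (0.33 log units; beyond the scatter) in this assay, so the higher number seen for methoxy is not shared by fluoro at this position. Fluoro and methyl, by contrast, cannot be told apart here, with a 1.8-fold higher number from compound 1 to compound 3 (0.26 log units; within the scatter) leaving methoxy alone in standing apart from the other two groups. Nothing measured here explains why methoxy stands apart. The compounds shown leave open how chloro, hydroxyl, an amine or a longer chain such as ethoxy would read at this place. They also leave open whether the methoxy step holds with the group moved elsewhere on that ring.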